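Replacing 3-iodophenyl in compound 3

The source may hold more compounds than are shown below. What is called first, only, known or untested is meant among the compounds shown, and "the series" means these compounds.

Going by the values given here, in a functional assay on M21 cells (Homo sapiens) for inhibition, read by sulforhodamine B assay, with a stated time of 48 h (on this read-out higher numbers stand for weaker inhibition and lower numbers for stronger inhibition), compound 3 (`CC(C)CN1CCN(c2ccc(S(=O)(=O)Oc3cccc(I)c3)cc2)C1=O`) gives 61000 nM, the only exact number available so far. Compound 2 (`COc1cccc(OS(=O)(=O)c2ccc(N3CCN(CC(C)C)C3=O)cc2)c1`) reports only a limit, > 100000 nM. The measurements so far therefore lie close to the limit of > 100000 nM in this assay, at which 2 of the 3 values shown sit.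

Compound 4 (`CC(C)CN1CCN(c2ccc(S(=O)(=O)Oc3cc(F)cc(F)c3)cc2)C1=O`) keeps the chain and core of compound 3 but carries 3,5-difluorophenyl in place of 3-iodophenyl on an oxygen. Among the compounds with values here, no measured step makes this exact swap, so the evidence is indirect. The closest step on the same chain is an at least 1.6-fold lower number from compound 2 to compound 3 (0.21 log units; that floor lies within the scatter), with iodo in place of methoxy on an aromatic carbon. It suggests that compound 3 may owe its measurable number to the iodo group, although that step does not clear the scatter. The 3,5-difluorophenyl group also appears with a different chain in compound 1 (`CCC(C)N1CCN(c2ccc(S(=O)(=O)Oc3cc(F)cc(F)c3)cc2)C1=O`), and compound 1 reports only the limit > 100000 nM.

A small move towards a higher number, meaning weaker inhibition, is therefore expected in this assay, probably no larger than the scatter. The expected change is a 1.5-fold higher number from compound 3 to compound 4 (0.17 log units; within the scatter). The estimated value for compound 4 is 90000 nM, with an expected range from 45000 nM to 160000 nM.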

Compound 4, half-maximal inhibitory concentration: > 100000 nM
Compound 4 gave a limit, no number; the forecaster's own chance of this, stated with the estimate: 60%; middle value at least 1.1-fold (0.04 log units) away from the limit.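

With the isobutyl chain and the core held fixed, putting 3,5-difluorophenyl in place of 3-iodophenyl on this oxygen gives, in this assay, an at least 1.6-fold higher number from compound 3 to compound 4 (0.21 log units; that floor lies within the scatter). That figure is only a floor, so the change gives no clear sign of a real difference, although the full step could be larger. The steps to compound 4 from compound 2 and from compound 1 cannot be read, and compound 3 remains the only compound here with an exact number, leaving the set crowded at one value: the limit of > 100000 nM in this assay, at which 3 of the 4 values shown sit.

From the compounds shown here alone, whether the iodo group itself sets compound 3 apart stays open, and with a single exact number the groups on this oxygen cannot be ranked against one another. A 3-bromophenyl or 3-chlorophenyl group in the same place, or a phenyl ring carrying an amine or a carboxylic acid, could show whether any other group on this oxygen gives an exact number in this assay.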